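This account rests on a few compounds, and the source may have more. Where it says the series, first, only, none or still open, it means among the compounds named here.

In a functional assay on PLC-PRF-5 cells (Homo sapiens) for inhibition, read by MTT assay, with a stated time of 72 h (on this read-out lower numbers stand for stronger inhibition and higher numbers for weaker inhibition), compound 1 `CNC(=O)CCCCCCCn1nc(-c2cnc3[nH]ccc3c2)c2c(N)ncnc21` gives 35900 nM. Compound 2 `Nc1nc2cc(-c3nn(CCCCCCCCCC(=O)NO)c4ncnc(N)c34)ccc2o1` gives > 100000 nM in this assay, which is a limit of the assay and not a number. Compound 3 `Nc1ncnc2c1c(-c1cnc3[nH]ccc3c1)nn2CCCCCCCCCC(=O)NO` differs from compound 2 by one exchange on an aromatic carbon: a group of 9 heavy atoms (7 carbon, 2 nitrogen; one five-membered aromatic ring with 1 hetero atom, one six-membered aromatic ring with 1 hetero atom) in place of a group of 10 heavy atoms (7 carbon, 2 nitrogen, 1 oxygen; one five-membered aromatic ring with 2 hetero atoms, one six-membered aromatic ring of carbon only), on an aromatic carbon. Stronger inhibition than with compound 2 is expected, resting on compound 1, which carries the entering group and gives 35900 nM. The size of the change is estimated as an at least 8.3-fold lower number from compound 2 to compound 3 (0.92 log units; beyond the scatter), expected to lie beyond the scatter. For compound 3 the estimate is 12000 nM, with an expected range of 1500 nM to 80000 nM.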

Compound 3, half-maximal inhibitory concentration: 34200 nM
Compound 3: middle estimate off by 2.9-fold (0.45 log units), on the low side; measured number inside the range.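

In this assay the group entering at this aromatic carbon in place of 2-amino-1,3-benzoxazol-5-yl gives an at least 2.9-fold lower number from compound 2 to compound 3 (0.46 log units; beyond the scatter), so the group at this position alone brings the series off the limit. The chain-end exchange, 2-(hydroxycarbamoyl)ethyl in place of methylcarbamoyl, gives a 1.0-fold lower number from compound 1 to compound 3 (0.02 log units; within the scatter), so with this entering group the two chain ends are not told apart. Compound 2 stands at a limit of the assay, not a number, so that step has no upper size: the limit of > 100000 nM in this assay, at which 1 of the 3 values shown sits.

Still open, on these data alone, is how 2-amino-1,3-benzoxazol-5-yl reads with the methylcarbamoyl chain end. Also open, as far as these compounds go, is how a carboxylic acid at the chain end, a longer chain, or an amine on the aromatic carbon would read.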